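The source may report more compounds than this note shows. Statements on the series, on what has been measured and on what is new or still open speak of the compounds shown alone.

Three compounds share one core and differ only in the group attached to it. In a functional assay on BMMC cells (Mus musculus, strain C57BL/6) for inhibition, with stated times of 5 days and 48 h (on this read-out higher numbers stand for weaker inhibition and lower numbers for stronger inhibition), compound 1 `C=C1CC[C@@H]2[C@](C)(CNCc3ccc(OC)cc3)[C@H](O)CC[C@@]2(C)[C@@H]1/C=C/C1=CCOC1=O` gives 750 nM, compound 2 `C=C1CC[C@@H]2[C@](C)(CNCc3ccc(O)c(O)c3)[C@H](O)CC[C@@]2(C)[C@@H]1/C=C/C1=CCOC1=O` gives 9440 nM, and compound 3 `C=C1CC[C@@H]2[C@](C)(CNCc3ccc(C#N)cc3)[C@H](O)CC[C@@]2(C)[C@@H]1/C=C/C1=CCOC1=O` gives 1130 nM. Compound 3 thus holds the second highest of the three numbers: its nearest neighbour is compound 1, with a 1.5-fold higher number from compound 1 to compound 3 (0.18 log units; within the scatter), and its furthest is compound 2, with an 8.4-fold lower number from compound 2 to compound 3 (0.92 log units; beyond the scatter).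

Compound 4 `C=C1CC[C@H]2[C@@](C)(CC[C@@H](O)[C@@]2(C)C(=O)NCc2ccc(Br)cc2)[C@@H]1/C=C/C1=CCOC1=O` differs from compound 3 by a group of 11 heavy atoms (8 carbon, 1 nitrogen, 1 oxygen, 1 bromine; one six-membered aromatic ring of carbon only) in place of a group of 11 heavy atoms (9 carbon, 2 nitrogen; one six-membered aromatic ring of carbon only), on a saturated ring carbon. The steps that touch this region are the swaps of the aromatic group, namely a 13-fold higher number from compound 1 to compound 2 (1.10 log units; beyond the scatter) and an 8.4-fold lower number from compound 2 to compound 3 (0.92 log units; beyond the scatter), while a 1.5-fold higher number from compound 1 to compound 3 (0.18 log units; within the scatter) shows that exchanging one small substituent on the aromatic ring for another did little. Among the compounds with values here, no measured step exchanges the amine linkage for the carbamoyl linkage, so that part of the change is uncharted. On balance, a step of a 1.4-fold higher number from compound 3 to compound 4 (0.15 log units; within the scatter) is expected, in the direction of weaker inhibition but of uncertain size. Compound 4 is therefore estimated at 1600 nM, with a range from 400 nM to 6500 nM.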

Compound 4, half-maximal inhibitory concentration: 3450 nM
Compound 4: middle estimate off by 2.2-fold (0.33 log units), on the low side; the measured number falls inside the stated range.
By their numbers in this assay, from the lowest: compounds 1 and 3 (each within the scatter of the next); then compound 4; then compound 2.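

In this assay, placing (4-bromobenzyl)carbamoyl on this saturated ring carbon gives weaker inhibition than either of the two better side groups with an amine link (a 3.1-fold higher number from compound 3 to compound 4 (0.48 log units; beyond the scatter); a 4.6-fold higher number from compound 1 to compound 4 (0.66 log units; beyond the scatter)). The loss is real but limited, and this group still inhibits more strongly than the side group carrying 3,4-dihydroxyphenyl (a 2.7-fold lower number from compound 2 to compound 4 (0.44 log units; beyond the scatter)), so the position accepts a carbonyl-containing link without the largest loss seen so far. No measurement here explains this shift.

The change swaps the link and the ring substituent together, and the compounds shown do not separate the two contributions. A ((4-bromobenzyl)amino)methyl group on the same carbon would isolate the link, while a carboxylic acid there would test whether the benzyl part matters at all.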